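Trifluoromethyl added to two amide cores, cytotoxicity

This account rests on a few compounds, and the source may have more. Where it says the series, first, only, none or still open, it means among the compounds named here.

Compound 1 `CCS(=O)(=O)Nc1ccc(NC(=O)c2cccc(C(F)(F)F)c2)cc1C` and compound 2 `CCS(=O)(=O)Nc1ccc(NC(=O)c2cc(C(F)(F)F)cc(C(F)(F)F)c2)cc1C` share one core. Compound 3 `COc1cc(NC(=O)c2cccc(C(F)(F)F)c2)ccc1NS(=O)(=O)C(F)(F)F` and compound 4 `COc1cc(NC(=O)c2cc(C(F)(F)F)cc(C(F)(F)F)c2)ccc1NS(=O)(=O)C(F)(F)F` share another, and the difference between the two cores is not broken down here. In an ADME assay on RAW264.7 cells (Mus musculus) for cytotoxicity, read by MTT assay, with a stated time of 48 h (a lower number here means a stronger inhibitor, a higher number a weaker inhibitor), compound 1 gives 114000 nM and compound 2 gives 124000 nM. In this assay compound 3 gives 75200 nM; its values against compound 1 and compound 2 lie within the scatter, so no order among the three is drawn.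

The change from compound 1 to compound 2 is trifluoromethyl in place of hydrogen on an aromatic carbon and it made a 1.1-fold higher number from compound 1 to compound 2 (0.04 log units; within the scatter). The change from compound 3 to compound 4 is trifluoromethyl in place of hydrogen on an aromatic carbon, the same change at the same kind of place; it occurs twice among these compounds, and only the pair compound 1 to compound 2 is measured. Because a 1.1-fold higher number from compound 1 to compound 2 (0.04 log units; within the scatter) lies within the scatter, compound 4 is expected to stay close to compound 3 in this assay, and the expected step is a 1.1-fold higher number from compound 3 to compound 4 (0.04 log units; within the scatter). Compound 4 is thus estimated at 82000 nM in this assay, with a range from 42000 nM to 160000 nM.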

Compound 4, half-maximal inhibitory concentration: > 250000 nM
Compound 4 was reported as a limit; the forecaster's own chance of this, stated with the estimate: 10%; middle value at least 3.0-fold (0.48 log units) from the limit.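

In this assay, trifluoromethyl in place of hydrogen on an aromatic carbon gives an at least 3.3-fold higher number from compound 3 to compound 4 (0.52 log units; beyond the scatter), so the change did not carry over with the same size from the core of compound 1 to the core of compound 3: the same change on two cores in this assay, a 1.1-fold higher number (0.04 log units; within the scatter) from compound 1 to compound 2 and an at least 3.3-fold higher number (0.52 log units; beyond the scatter) from compound 3 to compound 4, at least 3.0-fold (0.48 log units) apart, beyond the scatter of two such steps

For compound 4, > 250000 nM is a limit of the assay and not a number: the limit of > 250000 nM in this assay, at which 1 of the 4 values shown sits.

On these data alone, the true size of the step therefore remains unknown, and one pair on each core shows only that the outcome of this change differed between these two cores, not how it would behave on any other core.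

Which part of the cores goes with this gap remains open, as the difference between them is not resolved into single changes among the compounds shown. Also open, as far as these compounds go, is how a different group in the same place, such as a nitrile or a carboxylic acid, would behave on either core.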